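Methyl to Trifluoromethyl: Expecting the Next Measurement

The source may hold more compounds than are shown below. What is called first, only, known or untested is meant among the compounds shown, and "the series" means these compounds.

Compound 1 `Cc1ccc(CN2CCC(NC(=O)C(C)(C)Oc3ccc(C(=O)c4ccc(Cl)cc4)cc3)CC2)cc1`: 8560 nM
Compound 2 `Cc1ccc(CN2CCC(NC(=O)C(C)(C)CCCOc3cc(C)ccc3C)CC2)cc1`: 6540 nM

In a functional assay on RAW264.7 cells (Mus musculus) for inhibition, read by polymerase chain reaction, with stated times of 12 h and 6 h (on this read-out higher numbers stand for weaker inhibition and lower numbers for stronger inhibition), compound 1 gives 8560 nM, and compound 2 gives 6540 nM. The two numbers lie within the usual scatter of each other, so compound 1 stands alongside compound 2 rather than apart from it. Compound 3 `CC(C)(Oc1ccc(C(=O)c2ccc(Cl)cc2)cc1)C(=O)NC1CCN(Cc2ccc(C(F)(F)F)cc2)CC1` differs from compound 1 by trifluoromethyl in place of methyl on an aromatic carbon. Within the data shown here, no measured pair shows this change, so nothing here sets its size. The step of a 1.2-fold lower number from compound 1 to compound 3 (0.09 log units; within the scatter) is expected to stay small, with no direction beyond the scatter. Compound 3 is estimated at 7000 nM, within 3000 nM to 20000 nM.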

Compound 3, half-maximal inhibitory concentration: 4400 nM
The estimate for compound 3 lay 1.6-fold (0.20 log units) above the measured number, within the range that was stated.
By their numbers in this assay, from the lowest: compounds 3, 2 and 1 (each within the scatter of the next).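

In this assay, among these compounds, trifluoromethyl in place of methyl on an aromatic carbon, para to a large group, gives a 1.9-fold lower number from compound 1 to compound 3 (0.29 log units; within the scatter) and so provides the first reading of a change at this position. Four heavy atoms stand there in place of one, and the step stays within the scatter. On this core, the position therefore tolerates this change without a difference that the read-out can separate.

As far as these compounds go, whether a nitrile, an amine or a carboxylic acid at this place would move the number beyond the scatter stays open, as does the effect of the same change on compound 2. No available evidence accounts for the result.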